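The compounds below may be only part of what the source reports. "The series", "measured", "known", "first", "only" and "open" are said of these compounds alone.

Working notes on the series, read in a functional assay on SMMC-7721 cells (Homo sapiens) for antiproliferative activity, read by MTT assay, with a stated time of 48 h; a higher number here means a weaker inhibitor, a lower number a stronger inhibitor. Compound 1 `CC(C)=CCC[C@]1(C)/C=C/[C@@H](OC(=O)C=C(C)C)[C@](C)(O)/C=C/C(=O)/C(C[Si](C)(C)C(C)(C)C)=C\C1` gives 4000 nM, compound 2 `CC(C)=CCC[C@]1(C)/C=C/[C@@H](OC(=O)C=C(C)C)[C@](C)(O)/C=C/C(=O)/C(CN=[N+]=[N-])=C\C1` gives 3080 nM, and compound 3 `CSC(=S)OC/C1=C/C[C@](C)(CCC=C(C)C)/C=C/[C@@H](OC(=O)C=C(C)C)[C@](C)(O)/C=C/C1=O` gives 720 nM, the lowest of the three numbers. Compound 4 `CCN(CC)C(=O)/C1=C/C[C@](C)(CCC=C(C)C)/C=C/[C@@H](OC(=O)C=C(C)C)[C@](C)(O)/C=C/C1=O` is still unmeasured and carries this change: a group of 7 heavy atoms (5 carbon, 1 nitrogen, 1 oxygen; no ring) in place of a group of 6 heavy atoms (3 carbon, 1 oxygen, 2 sulfur; no ring), on a double-bonded ring carbon. Among the measured compounds shown here, three measured steps bear on it, all swaps on a saturated chain carbon bound to a double-bonded ring carbon. The step of a 1.3-fold lower number from compound 1 to compound 2 (0.11 log units; within the scatter) stays within the scatter, while a 4.3-fold lower number from compound 2 to compound 3 (0.63 log units; beyond the scatter) and a 5.6-fold lower number from compound 1 to compound 3 (0.74 log units; beyond the scatter) are modest and beyond it. Compound 3 alone stands apart on these steps, and its group leaves here. For the measured compounds named here, no measured step changes a group directly on the double-bonded ring carbon, so the expectation is loose. A modest step toward a higher number is expected in this assay, returning to about the level of compound 2 at 3080 nM. The expected step is a 3.5-fold higher number from compound 3 to compound 4 (0.54 log units; beyond the scatter). For compound 4 the estimated value is 2500 nM, with an expected range from 800 nM to 7000 nM.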

Compound 4, half-maximal inhibitory concentration: 13800 nM
Compound 4: the middle estimate sits 5.5-fold (0.74 log units) below what was measured, outside the stated range (above it).
By their numbers in this assay, from the lowest: compound 3; then compounds 2 and 1 (each within the scatter of the next); then compound 4.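

Compound 4 is the only compound shown with a carbonyl-linked group directly on the double-bonded ring carbon, and in this assay it has the highest number of the series: a 19-fold higher number from compound 3 to compound 4 (1.28 log units; beyond the scatter), a 4.5-fold higher number from compound 2 to compound 4 (0.65 log units; beyond the scatter) and a 3.5-fold higher number from compound 1 to compound 4 (0.54 log units; beyond the scatter). Among the compounds shown here, the earlier swaps on the saturated chain carbon showed only that the group there could alter the number; diethylcarbamoyl on the ring carbon now lies beyond the scatter from all three, including the silicon-bearing group and azidomethyl, which are themselves within the scatter of each other. Nothing at hand accounts for this rise.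

Compound 4 changes both the attachment and the end of the group, so the contribution of each remains unresolved. A diethylaminomethyl group would test the amine without the carbonyl, while a carboxylic acid or methyl ester on the ring carbon would test the carbonyl without the diethylamino end.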